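This account rests on a few compounds, and the source may have more. Where it says the series, first, only, none or still open, it means among the compounds named here.

Measured in an ADME assay on HEK293 cells (Homo sapiens) for cytotoxicity, read by resazurin assay, with a stated time of 48 h; a higher number here means that more compound is tolerated, a lower number that less compound is tolerated:

- compound 1 (`O=S(=O)(Nc1ccc2oc(-c3ccccc3)nc2c1)c1cccc(C(F)(F)F)c1`) gives > 100000 nM, which is a limit of the assay and not a number
- compound 2 (`O=S(=O)(Nc1ccc2oc(-c3ccccc3)nc2c1)c1cccc(F)c1`) gives 68000 nM
- compound 3 (`COc1cccc(S(=O)(=O)Nc2ccc3oc(-c4ccccc4)nc3c2)c1`) gives 63000 nM

Among the measured compounds shown here, compound 3 stands level with compound 2, the only other compound with a true number, since the step between them is a 1.1-fold lower number from compound 2 to compound 3 (0.03 log units; within the scatter). Both steps out of compound 1 give only floors, namely an at least 1.4-fold lower number from compound 1 to compound 2 (0.16 log units; that floor lies within the scatter) and an at least 1.5-fold lower number from compound 1 to compound 3 (0.20 log units; that floor lies within the scatter).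

The next compound is compound 4 (`O=S(=O)(Nc1ccc2oc(-c3ccccc3)nc2c1)c1ccccc1Cl`), which has 2-chlorophenyl in place of 3-methoxyphenyl on a sulfonyl sulfur. For the measured compounds named here, no measured compound carries 2-chlorophenyl, so the guide is indirect. All three measured steps alter the same aromatic group on the sulfonyl sulfur, and none is shown to exceed the scatter in this assay. With the step of a 1.1-fold lower number from compound 2 to compound 3 (0.03 log units; within the scatter) as the firmest guide, no change beyond the scatter is expected. The estimated step is a 1.1-fold higher number from compound 3 to compound 4 (0.05 log units; within the scatter). For compound 4 the expected value is 70000 nM, with an estimated range from 35000 nM to 100000 nM.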

Compound 4, half-maximal cytotoxic concentration: 73000 nM
Compound 4: middle estimate off by 1.0-fold (0.02 log units), on the low side; low and high end bracket the measured number.
By their numbers in this assay, from the lowest: compounds 3, 2 and 4 (each within the scatter of the next). At a limit, above all of these: compound 1.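

In this assay, 2-chlorophenyl in place of 3-methoxyphenyl on a sulfonyl sulfur gives a 1.2-fold higher number from compound 3 to compound 4 (0.06 log units; within the scatter), and 2-chlorophenyl in place of 3-fluorophenyl gives a 1.1-fold higher number from compound 2 to compound 4 (0.03 log units; within the scatter). The earlier true numbers came only from 3-fluorophenyl and 3-methoxyphenyl, so compound 4 adds a differently substituted phenyl group at this place. It stands level with both, and at this place the exchange of these three groups has not yet moved the number beyond the scatter.

Every group shown here on the sulfonyl sulfur is a substituted phenyl ring, so it stays open whether an amine or a carboxylic acid on that ring, or a simple alkyl chain in its place, would shift the number beyond the scatter. Compound 4 also cannot be placed against compound 1, whose > 100000 nM is a limit of the assay and not a number: the limit of > 100000 nM in this assay, at which 1 of the 4 values shown sits.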